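Capping the Phenol: From Compound 3 to Compound 4

A few compounds are considered here, and "the series" means these few. Any claim that something is new, unique, unknown or untested is made for them only; others in the source may bear on it.

Compound 1, `O=C1/C(=C/c2cccc(F)c2)Cc2cc(O)ccc21`, gives 84 nM in an assay on isolated protein for inhibition of Amine oxidase [flavin-containing] B (Homo sapiens), read by fluorescence and spectrophotometry, with a stated time of 20 min; a higher number here means a weaker inhibitor, a lower number a stronger inhibitor.
Compound 2, `O=C1/C(=C/c2cccc(Cl)c2)Cc2cc(O)ccc21`, gives 30 nM in this assay.
Compound 3, `O=C1/C(=C/c2cccc(O)c2)Cc2cc(O)ccc21`, gives 966 nM in this assay.

Compound 3 stands at the top of the three numbers in this assay: the change from compound 1 reads a 12-fold higher number from compound 1 to compound 3 (1.06 log units; beyond the scatter), and that from compound 2 reads a 32-fold higher number from compound 2 to compound 3 (1.51 log units; beyond the scatter), both beyond the scatter. The two halogen compounds differ less from each other, with a 2.8-fold lower number from compound 1 to compound 2 (0.45 log units; beyond the scatter).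

Compound 4, `COc1cccc(/C=C2\Cc3cc(O)ccc3C2=O)c1`, is reached from compound 3 by methyl in place of hydrogen on an oxygen on an aromatic ring. For the measured compounds named here, no measured pair shows a methoxy group, so the bearing of the measured steps is indirect: they only show that the hydroxy compound is the weakest of the three, and that replacing hydroxy by a group without a donor lowers the number by a large margin. On that basis compound 4 is expected to give a lower number than compound 3, though likely short of the halogen compounds; the estimated step reads a 3.9-fold lower number from compound 3 to compound 4 (0.59 log units; beyond the scatter). The estimate for compound 4 in this assay is 250 nM, with a range from 60 nM to 1000 nM.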

Compound 4, half-maximal inhibitory concentration: 471 nM
For compound 4 the middle estimate is 1.9-fold (0.28 log units) below the measured one; measured number inside the range.
By their numbers in this assay, from the lowest: compound 2; then compound 1; then compound 4; then compound 3.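

Capping the hydroxy as methoxy at this position gives only a small gain in this assay, with a 2.1-fold lower number from compound 3 to compound 4 (0.31 log units; beyond the scatter), so removing that hydrogen alone recovers little of the gap to the halogen compounds. Methoxy remains clearly behind both halogens, with a 5.6-fold higher number from compound 1 to compound 4 (0.75 log units; beyond the scatter) and a 16-fold higher number from compound 2 to compound 4 (1.20 log units; beyond the scatter), which places it much nearer to hydroxy than to chloro, the best of the four groups at this position. Nothing in hand accounts for this order among the four groups.

The compounds shown leave open how an amine, a carboxylic acid or a longer chain on the oxygen would read at this position. As far as these compounds go, the hydroxy on the shared core is the same in all four compounds, so what a change there would do also remains unknown.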